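Oxime ether change from compound 3 to compound 4

The source may hold more compounds than are shown below. What is called first, only, known or untested is meant among the compounds shown, and "the series" means these compounds.

Measured compounds, each value a limit and not a number:
- compound 1 `CN1CCCCC1CCO/N=C1C(=C2/C(=O)Nc3ccc(F)cc32)/Nc2ccccc2/1`: > 2000 nM
- compound 2 `CN(C)CCCO/N=C1C(=C2/C(=O)Nc3ccccc32)/Nc2ccccc2/1`: > 2000 nM
- compound 3 `CN1CCCC1CCO/N=C1C(=C2/C(=O)Nc3ccccc32)/Nc2ccccc2/1`: > 2000 nM

In a toxicity assay on IMR-90 cells (Homo sapiens) for cytotoxicity, read by MTT assay, with a stated time of 72 h (on this read-out higher numbers stand for weaker inhibition and lower numbers for stronger inhibition), compound 3 gives > 2000 nM, which is a limit. It has no numerical rank in the series, as the whole measured set stands at the limit of > 2000 nM in this assay, at which 3 of the 3 values shown sit.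

Compound 4 `CN1CCC(O/N=C2C(=C3/C(=O)Nc4ccccc43)/Nc3ccccc3/2)CC1` replaces the 2-(1-methylpyrrolidin-2-yl)ethyl of compound 3 with 1-methylpiperidin-4-yl on an oxygen: 1-methylpiperidin-4-yl in place of 2-(1-methylpyrrolidin-2-yl)ethyl on an oxygen. The core stays the same, and the entering group again has no net charge.

Among the compounds with values here, the only measured step on this substituent is a step that the two limits leave unreadable from compound 2 to compound 3. Within the data shown here, it gives no size to carry forward, and no measured step covers the change to 1-methylpiperidin-4-yl. The expectation therefore rests on the position of compound 3 at > 2000 nM and on the other two limits in the set. No step beyond the scatter is expected in this assay, in either direction, and another limit is the most likely report. The estimated change is a step that the limit leaves unreadable from compound 3 to compound 4. For compound 4 the expected value is 3000 nM, with an estimated range from 1200 nM to 10000 nM.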

Compound 4, half-maximal inhibitory concentration: > 2000 nM
Compound 4 was reported as a limit; the forecaster's own chance of this, stated with the estimate: 80%; the middle value is on the limit's open side.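

In this assay compound 4 gives > 2000 nM, which is a limit, so no step can be read from compound 2 or compound 3 to compound 4. The compounds shown leave open whether the groups on the oxime ether oxygen differ at all in this assay, and how they would rank: the limit of > 2000 nM in this assay, at which 4 of the 4 values shown sit.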